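The source may report more compounds than this note shows. Statements on the series, on what has been measured and on what is new or still open speak of the compounds shown alone.

Compound 1 `Clc1ccc(C2=CC3CNCC(C2)C3)cn1` and compound 2 `Fc1ccc(C2=CC3CNCC(C2)C3)cn1` share one core and differ at a single aromatic carbon. In an in vitro functional assay on SH-EP1 cells for agonist activity at Neuronal acetylcholine receptor; alpha4/beta2 (Homo sapiens), read by FLIPR and calcium flux (a higher number here means that more compound is needed for the effect, a lower number that less compound is needed), compound 1 gives 35 nM, and compound 2 gives 85 nM; the step of a 2.4-fold higher number from compound 1 to compound 2 (0.39 log units; beyond the scatter) is modest. Compound 3 `CN1CC2C=C(c3ccc(F)nc3)CC(C2)C1` carries a methyl on the amine nitrogen of the ring. In this assay compound 3 is reported only as a limit, > 10000 nM. The step of an at least 110-fold higher number from compound 2 to compound 3 (2.07 log units; beyond the scatter) is large, ending at the limit of > 10000 nM in this assay, at which 1 of the 3 values shown sits. Among the numbers shown, compound 2 stands highest of the two, with compound 1 as its nearest neighbour below, while the third value is a limit rather than a number.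

Compound 4 `C1=C(c2ccc(-c3ccccc3)nc2)CC2CNCC1C2` has not yet been measured. Its change from compound 2 is phenyl in place of fluoro on an aromatic carbon. Going by the values given here, no measured step is of this kind: the halogen swap at the same aromatic carbon was modest, and the methylation of the amine nitrogen was large but elsewhere. The entering phenyl is a larger change than the halogen swap was. A loss beyond the scatter is expected, though not one reaching a limit. Compound 4 is therefore expected to give about 400 nM, between 60 nM and 3000 nM, in this assay. The expected step is a 4.7-fold higher number from compound 2 to compound 4 (0.67 log units; beyond the scatter).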

Compound 4, half-maximal effective concentration: 9660 nM
Beside the measured number, compound 4's estimate is 24-fold (1.38 log units) below it; the whole stated range lies below it.
By their numbers in this assay, from the lowest: compound 1; then compound 2; then compound 4. At a limit, above all of these: compound 3.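

In this assay, going by these compounds alone, the halogen swap had moved the number only modestly, with a 2.4-fold higher number from compound 1 to compound 2 (0.39 log units; beyond the scatter), so the earlier compounds showed this position next to the ring nitrogen accepting a change between chloro and fluoro. Phenyl in place of fluoro shows that the same position can also carry a large penalty, with a 110-fold higher number from compound 2 to compound 4 (2.06 log units; beyond the scatter), and phenyl in place of chloro gives a 280-fold higher number from compound 1 to compound 4 (2.44 log units; beyond the scatter). The compounds shown offer no measurement that explains this loss.

As far as these compounds go, whether a small group such as methyl or methoxy at this position stays close to the halogens or falls towards phenyl remains open. So does whether a saturated ring such as cyclohexyl, or a phenyl carrying an amine, would behave as phenyl itself does.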